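The compounds below may be only part of what the source reports. "The series", "measured", "known", "first", "only" and "open" are said of these compounds alone.

Three compounds sharing the core of compound 1 `O=C(O)c1cc(-c2ccc(-c3ccc(Cl)cc3Cl)cc2)n(-c2ccc(Cl)cc2Cl)n1` have been tested in an assay on isolated protein for inhibition of methionine--tRNA ligase, cytoplasmic (Homo sapiens); a higher number here means a weaker inhibitor, a lower number a stronger inhibitor. Compound 1 gives 11900 nM. Compound 2 `O=C(O)c1cccc(-c2ccc(-c3cc(C(=O)O)nn3-c3ccc(Cl)cc3Cl)cc2)c1` gives 40900 nM, and compound 3 `O=C(O)c1cc(-c2ccc(-c3ccc(F)c(Cl)c3)cc2)n(-c2ccc(Cl)cc2Cl)n1` gives 20900 nM. Compound 3 thus stands second highest of the three numbers: its nearest neighbour is compound 1, and a 1.8-fold higher number from compound 1 to compound 3 (0.24 log units; within the scatter), so the two values lie within the scatter; its furthest is compound 2, and a 2.0-fold lower number from compound 2 to compound 3 (0.29 log units; within the scatter), again within the scatter. Among the compounds with values here, the only step beyond the scatter is a 3.4-fold higher number from compound 1 to compound 2 (0.54 log units; beyond the scatter).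

Compound 4 `O=C(O)c1cc(-c2ccc(-c3ccc(C(F)(F)F)cc3)cc2)n(-c2ccc(Cl)cc2Cl)n1` differs from compound 3 in one place: 4-(trifluoromethyl)phenyl in place of 3-chloro-4-fluorophenyl on an aromatic carbon. Within the data shown here, two measured steps bear on this. a 1.8-fold higher number from compound 1 to compound 3 (0.24 log units; within the scatter) exchanges one halogenated phenyl for another and stays within the scatter. a 2.0-fold lower number from compound 2 to compound 3 (0.29 log units; within the scatter) removes a carboxylic acid and also stays within the scatter; the one step beyond the scatter, a 3.4-fold higher number from compound 1 to compound 2 (0.54 log units; beyond the scatter), introduces that carboxylic acid. The exchange from compound 3 to compound 4 introduces no acid and keeps a substituted phenyl with no net charge, so no step beyond the scatter in this assay is expected in either direction: a 1.2-fold lower number from compound 3 to compound 4 (0.06 log units; within the scatter). The value for compound 4 is estimated at 18000 nM, with a range from 7000 nM to 45000 nM.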

Compound 4, half-maximal inhibitory concentration: 33500 nM
The estimate for compound 4 lay 1.9-fold (0.27 log units) below the measured number; low and high end bracket the measured number.
By their numbers in this assay, from the lowest: compounds 1, 3, 4 and 2 (each within the scatter of the next, the first and the last beyond it).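

The trifluoromethyl compound cannot be separated in this assay from either neighbouring replacement at this position, on an aromatic carbon para to a large group: the data give a 1.6-fold higher number from compound 3 to compound 4 (0.20 log units; within the scatter) and a 1.2-fold lower number from compound 2 to compound 4 (0.09 log units; within the scatter). What is new is a 2.8-fold higher number from compound 1 to compound 4 (0.45 log units; beyond the scatter), a second step beyond the scatter from compound 1 and the first that brings in no carboxylic acid, so an acid on this phenyl is not required for a step of that size, although compound 3, also without that acid, stays within the scatter of compound 1. The data available offer no explanation for these differences.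

The compounds shown leave open how an amine, a methoxy group or a nitrile on this outer phenyl would compare, since every group so far is a halogen, a trifluoromethyl or a carboxylic acid. They also leave open what an amide or an ester would do in place of the carboxylic acid on the shared core, which all four compounds carry unchanged.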